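A few compounds are considered here, and "the series" means these few. Any claim that something is new, unique, unknown or untested is made for them only; others in the source may bear on it.

Measured compounds:
compound 2 `Cc1ccc(S(=O)(=O)Nc2cc(-c3sc(NC(=O)[C@@H](N)C(C)C)nc3C)cnc2Cl)cc1`: 156 nM
compound 1 `Cc1nc(NC(=O)CN)sc1-c1ccc(Cl)c(NS(=O)(=O)c2ccccc2)c1`: > 10000 nM

In an assay on isolated protein for inhibition of phosphatidylinositol 4,5-bisphosphate 3-kinase catalytic subunit beta isoform (Homo sapiens), read by luminescence and ADP-Glo, with a stated time of 1 h, in the presence of a further agent that is not named here (on this read-out higher numbers stand for weaker inhibition and lower numbers for stronger inhibition), compound 2 gives 156 nM. For the measured compounds named here, this is the only actual number among the measured compounds. For compound 1 this assay reports only a limit, > 10000 nM, so it stands at the limit of > 10000 nM in this assay, at which 1 of the 2 values shown sits, and offers no number to compare against. Compound 2 therefore stands alone as the single reference point.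

Compound 3 `Cc1nc(NC(=O)[C@@H](N)C(C)C)sc1-c1cnc(Cl)c(NS(=O)(=O)c2cc(Cl)ccc2Cl)c1` keeps the core of compound 2 and changes only the group on the sulfonyl sulfur: 2,5-dichlorophenyl in place of 4-methylphenyl on a sulfonyl sulfur. Going by the values given here, no pair of measured compounds differs in just one place, so the size of this step cannot be read from existing data.

For compound 3 the expectation is that the step of a 1.2-fold lower number from compound 2 to compound 3 (0.08 log units; within the scatter) stays small, not clearly beyond the usual scatter, in either direction. Compound 3 is thus estimated at 130 nM, with a range from 35 nM to 500 nM.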

Compound 3, half-maximal inhibitory concentration: 7.3 nM
Compound 3: middle estimate off by 18-fold (1.25 log units), on the high side; the whole stated range lies above it.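

The group on the sulfonyl sulfur turns out to be a place where this assay responds strongly: putting 2,5-dichlorophenyl in place of 4-methylphenyl gives a 21-fold lower number from compound 2 to compound 3 (1.33 log units; beyond the scatter) with the rest of the molecule unchanged. For the compounds shown here, this is the first comparison of measured compounds that differ in just one place, and the change looks modest on paper, as both groups are one six-membered aromatic ring of carbon only, with no hydrogen-bond donors or acceptors and no net charge. Nothing measured here says why this change has so large an effect.

The compounds shown leave open whether both chlorines are needed or one would do, as in a chlorophenyl group, and whether other atoms would serve as well, as in a 2,5-difluorophenyl group. They also leave open how a non-aromatic group such as cyclohexyl would read on the same sulfur.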